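Replacing the Phenyl Group of Compound 3

This account rests on a few compounds, and the source may have more. Where it says the series, first, only, none or still open, it means among the compounds named here.

In a functional assay on A549 cells (Homo sapiens) for inhibition, read by CCK-8 assay, with a stated time of 48 h (a higher number here means a weaker inhibitor, a lower number a stronger inhibitor), compound 1 (`COc1cc(-c2ccnc3cc(-c4ccc(C)cc4)nn23)cc(OC)c1OC`) gives 3 nM while compound 2 (`COc1cc(-c2ccnc3cc(-c4ccc(C)c(C)c4)nn23)cc(OC)c1OC`) gives 272 nM and compound 3 (`COc1cc(-c2ccnc3cc(-c4ccccc4)nn23)cc(OC)c1OC`) gives 208 nM in the same test. Compound 3 thus sits level with compound 2, within the scatter, and well behind compound 1. Compound 4 (`COc1cc(-c2ccnc3cc(-c4ccc5c(ccn5C)c4)nn23)cc(OC)c1OC`) has 1-methyl-1H-indol-5-yl in place of phenyl (1-methyl-1H-indol-5-yl in place of phenyl on an aromatic carbon) on the same aromatic carbon. Two measured steps change this group: a 69-fold higher number from compound 1 to compound 3 (1.84 log units; beyond the scatter) was large, whereas a 1.3-fold lower number from compound 2 to compound 3 (0.12 log units; within the scatter) stayed within the scatter. Among the measured compounds shown here, no measured compound carries an indole, so the size is hard to call. In this assay a moderate step toward a lower number is expected, namely a 4.2-fold lower number from compound 3 to compound 4 (0.62 log units; beyond the scatter) with wide uncertainty. The estimated value for compound 4 is 50 nM within a range of 5 nM to 400 nM as a rough guide.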

Compound 4, half-maximal inhibitory concentration: 15 nM
Compound 4: middle estimate off by 3.3-fold (0.52 log units), on the high side; low and high end bracket the measured number.
By their numbers in this assay, from the lowest: compound 1; then compound 4; then compounds 3 and 2 (each within the scatter of the next).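

At this aromatic carbon, a group of two fused rings is tolerated: in this assay the 1-methyl-1H-indol-5-yl group gives a 14-fold lower number from compound 3 to compound 4 (1.14 log units; beyond the scatter) and an 18-fold lower number from compound 2 to compound 4 (1.26 log units; beyond the scatter). Size alone therefore does not set the outcome here, yet the indole still falls short of 4-methylphenyl, with a 5.0-fold higher number from compound 1 to compound 4 (0.70 log units; beyond the scatter). Nothing measured here explains these steps.

Still open, going by these compounds, is whether the methyl on the indole nitrogen matters. Also open, on these data alone, is how a phenyl ring bearing an amine or a carboxylic acid would compare with 4-methylphenyl.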